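Swapping one side group on a shared core

This account rests on a few compounds, and the source may have more. Where it says the series, first, only, none or still open, it means among the compounds named here.

Measured in a physicochemical assay for solubility, in phosphate buffer, measured as thermodynamic solubility, with a stated time of 24 h, at pH 6.9; on this read-out higher numbers stand for higher solubility and lower numbers for lower solubility:
- compound 1 `CN(c1ncco1)c1cnc(NCc2c(F)ccc3c2CCO3)n2cnnc12`: 53000 nM
- compound 2 `CN(c1ccn(C)n1)c1cnc(NCc2c(F)ccc3c2CCO3)n2cnnc12`: 47000 nM
- compound 3 `CNC(=O)c1ccc(-c2cnc(NCc3c(F)ccc4c3CCO4)c3cn[nH]c(=O)c23)c(C)n1`: 16000 nM

Compound 2, at 47000 nM, cannot be told apart from compound 1, at 53000 nM, while compound 3, at 16000 nM, lies clearly lower than both.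

Going to compound 4 `O=C1CC2(CC2)CN1c1cnc(NCc2c(F)ccc3c2CCO3)n2cnnc12`, the methyl(1-methyl-1H-pyrazol-3-yl)amino group leaves and a group with no common name enters, on an aromatic carbon: a group of 8 heavy atoms (6 carbon, 1 nitrogen, 1 oxygen; one three-membered non-aromatic ring of carbon only, one five-membered non-aromatic ring with 1 hetero atom) in place of a group of 8 heavy atoms (5 carbon, 3 nitrogen; one five-membered aromatic ring with 2 hetero atoms), on an aromatic carbon.

Among the compounds with values here, only one measured step bears on this: a 1.1-fold lower number from compound 1 to compound 2 (0.05 log units; within the scatter). It exchanged one five-membered aromatic ring for another and stayed within the scatter. On that single guide, no change beyond the scatter is expected in this assay. Within the data shown here, no measured compound carries a non-aromatic group at this place, however, so the range must stay wide. The estimated step is a 1.1-fold higher number from compound 2 to compound 4 (0.03 log units; within the scatter). For compound 4 the estimated value is 50000 nM, with an expected range of 18000 nM to 140000 nM.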

Compound 4, solubility: 175000 nM
Estimate against measurement, compound 4: 3.5-fold (0.54 log units) below; the measured number lies above the stated range.
By their numbers in this assay, from the lowest: compound 3; then compounds 2 and 1 (each within the scatter of the next); then compound 4.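

At this place on the shared core, the earlier swap of one five-membered aromatic ring for another had stayed within the scatter, so it gave no sign that the group there mattered in this assay. Replacing the aromatic ring and its methylamino link with the fused non-aromatic ring group shows that this position can respond, with a 3.7-fold higher number from compound 2 to compound 4 (0.57 log units; beyond the scatter) and a 3.3-fold higher number from compound 1 to compound 4 (0.52 log units; beyond the scatter), even though compound 2 and compound 4 carry groups of the same heavy-atom count. No supporting measurement explains the rise.

The change removes the aromatic ring, adds a carbonyl and brings in a three-membered carbon ring all at once, so the part responsible stays unresolved. Going by these compounds, whether a plain five-membered lactam without the three-membered ring, or an open-chain amide, would give a similar number remains open.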